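The source may report more compounds than this note shows. Statements on the series, on what has been measured and on what is new or still open speak of the compounds shown alone.

In a functional assay on HepG2 cells (Homo sapiens) for antiproliferative activity, read by MTT assay, with a stated time of 48 h (on this read-out higher numbers stand for weaker inhibition and lower numbers for stronger inhibition), compound 1 (`Cc1ccc(S(=O)(=O)NCC(=O)N2Cc3ccccc3[C@@H](OCc3ccccc3)[C@@H]2CO)cc1`) gives 5050 nM and compound 2 (`Cc1ccc(S(=O)(=O)N[C@@H](C)C(=O)N2Cc3ccccc3[C@@H](OCc3ccccc3)[C@@H]2CO)cc1`) gives 5370 nM. For the measured compounds named here, these are the only two numbers so far, and compound 2 cannot be separated from compound 1 on them. Compound 3 (`Cc1ccc(S(=O)(=O)N[C@H](C(=O)N2Cc3ccccc3[C@@H](OCc3ccccc3)[C@@H]2CO)C(C)C)cc1`) has isopropyl in place of methyl on a saturated chain carbon bound to a carbonyl carbon and a sulfonamide nitrogen. Going by the values given here, one measured step bears on this change, the replacement of hydrogen by methyl at that same place in compound 2, and it is small: a 1.1-fold higher number from compound 1 to compound 2 (0.03 log units; within the scatter). Among the compounds with values here, no measured step covers a group as large as isopropyl, so this single step is thin support and the range stays wide. In this assay, no shift beyond the scatter is expected, and the expected step is a 1.1-fold higher number from compound 2 to compound 3 (0.05 log units; within the scatter). For compound 3 the estimated value is 6000 nM, with an expected range of 2500 nM to 14000 nM.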

Compound 3, half-maximal inhibitory concentration: 32000 nM
Beside the measured number, compound 3's estimate is 5.3-fold (0.73 log units) below it; the measured number lies above the stated range.
By their numbers in this assay, from the lowest: compounds 1 and 2 (each within the scatter of the next); then compound 3.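

At the saturated chain carbon bound to a carbonyl carbon and a sulfonamide nitrogen, this assay does respond to substitution: isopropyl in place of methyl gives a 6.0-fold higher number from compound 2 to compound 3 (0.78 log units; beyond the scatter), and isopropyl in place of hydrogen gives a 6.3-fold higher number from compound 1 to compound 3 (0.80 log units; beyond the scatter). The methyl step alone, a 1.1-fold higher number from compound 1 to compound 2 (0.03 log units; within the scatter), therefore does not predict what a larger alkyl group does here, and compound 3 shows weaker inhibition than compound 1 and compound 2. Nothing available accounts for this loss.

As far as these compounds go, whether the loss follows the branching of isopropyl or simply its carbon count remains open, and ethyl or a longer straight chain at this place would separate the two. Also open, from the compounds shown here alone, is how a group carrying an amine or a carboxylic acid would behave at this same carbon.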